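Ethoxy moved on the aniline ring: compound 3

The source may report more compounds than this note shows. Statements on the series, on what has been measured and on what is new or still open speak of the compounds shown alone.

Measured in an assay on mitochondria from L6 cells (Rattus norvegicus) for activation, with a stated time of 90 min (a lower number here means that less compound is needed, a higher number that more compound is needed for the effect), so far:
compound 1 `Fc1ccccc1Nc1nc2nonc2nc1Nc1ccccc1`, 2200 nM
compound 2 `CCOc1ccccc1Nc1nc2nonc2nc1Nc1ccccc1F`, 5600 nM

Compound 2 holds the higher of the two numbers in this assay, its nearest neighbour being compound 1 at 2200 nM. Within the data shown here, the single measured step, a 2.5-fold higher number from compound 1 to compound 2 (0.41 log units; beyond the scatter), is ethoxy in place of hydrogen on an aromatic carbon; it is modest but beyond the scatter.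

Compound 3 `CCOc1cccc(Nc2nc3nonc3nc2Nc2ccccc2F)c1` differs from compound 2 by 3-ethoxyphenyl in place of 2-ethoxyphenyl on a nitrogen on an aromatic ring. Among the measured compounds shown here, no measured step tells what moving the ethoxy from one carbon of that ring to another does, since both measured compounds either lack the group or carry it as 2-ethoxyphenyl. The only grounded expectation is that compound 3 stays near compound 2, with a step of a 1.2-fold lower number from compound 2 to compound 3 (0.09 log units; within the scatter) expected, which lies inside the scatter. Compound 3 is therefore estimated at 4500 nM, with a range from 1500 nM to 13000 nM.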

Compound 3, half-maximal effective concentration: 2200 nM
For compound 3 the middle estimate is 2.0-fold (0.31 log units) above the measured one; low and high end bracket the measured number.
By their numbers in this assay, from the lowest: compounds 1 and 3 (each within the scatter of the next); then compound 2.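

In this assay the place of the ethoxy matters: 3-ethoxyphenyl in place of 2-ethoxyphenyl on the nitrogen gives a 2.5-fold lower number from compound 2 to compound 3 (0.41 log units; beyond the scatter) even though the two compounds have the same atoms. Ethoxy in place of hydrogen now has two readings, a 2.5-fold higher number from compound 1 to compound 2 (0.41 log units; beyond the scatter) as 2-ethoxyphenyl and no change at the digits printed from compound 1 to compound 3 (within the scatter) as 3-ethoxyphenyl, so among these compounds the higher number goes with 2-ethoxyphenyl and not with the ethoxy group as such. No measurement shown here bears on the reason for this difference.

Still open, going by these compounds, is whether 3-ethoxyphenyl is a special case or whether other groups on that ring, such as methoxy, an amine or a carboxylic acid, would also keep the number close to that of compound 1. A longer chain on the oxygen is equally unresolved.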